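Aryl swap on the aromatic nitrogen: cytotoxicity notes

This account rests on a few compounds, and the source may have more. Where it says the series, first, only, none or still open, it means among the compounds named here.

Compound 1 `Cc1cc(=O)n(-c2cccc(F)c2)nc1C(=O)Nc1ccc(Oc2ncnc3ccsc23)c(F)c1` gives 7810 nM in a functional assay on HepG2 cells (Homo sapiens) for cytotoxicity, read by MTT assay, with a stated time of 72 h; on this read-out lower numbers stand for stronger inhibition and higher numbers for weaker inhibition. Compound 2 `Cc1ccc(-n2nc(C(=O)Nc3ccc(Oc4ncnc5ccsc45)c(F)c3)c(C)cc2=O)cc1` differs from it by 4-methylphenyl in place of 3-fluorophenyl on an aromatic nitrogen and in this assay compound 2 gives 17300 nM; the step is a 2.2-fold higher number from compound 1 to compound 2 (0.35 log units; beyond the scatter). Compound 3 `Cc1cc(=O)n(-c2cccc(F)c2)nc1C(=O)Nc1ccc(Oc2ncnc3sccc23)cc1` carries a different core; how the core of compound 1 and the core of compound 3 differ is not broken down here. In this assay compound 3 gives 18500 nM, within the scatter of compound 2 and beyond the scatter above compound 1. Compound 4 `Cc1ccc(-n2nc(C(=O)Nc3ccc(Oc4ncnc5sccc45)cc3)c(C)cc2=O)cc1`, not yet measured, differs from compound 3 by 4-methylphenyl in place of 3-fluorophenyl on an aromatic nitrogen, the same change at the same place as between compound 1 and compound 2. Going by the values given here, the expected step of a 2.2-fold higher number from compound 3 to compound 4 (0.33 log units; beyond the scatter) rests only on the single earlier step of a 2.2-fold higher number from compound 1 to compound 2 (0.35 log units; beyond the scatter). Compound 4 is accordingly estimated at 40000 nM in this assay, with a likely range from 18000 nM to 90000 nM.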

Compound 4, half-maximal inhibitory concentration: > 40000 nM
Compound 4 gave a limit, no number; the forecaster's own chance of this, stated with the estimate: 30%; the middle value sits exactly at the limit.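

In this assay, 4-methylphenyl in place of 3-fluorophenyl on the aromatic nitrogen gives an at least 2.1-fold higher number from compound 3 to compound 4 (0.33 log units; beyond the scatter). Set beside the earlier step, the direction of the change carries from the core of compound 1 to the core of compound 3, but the size of the change on the second core stays unsettled: the same change on two cores in this assay, a 2.2-fold higher number (0.35 log units; beyond the scatter) from compound 1 to compound 2 and an at least 2.1-fold higher number (0.33 log units; beyond the scatter) from compound 3 to compound 4; the limit leaves it open whether they differ. Compound 4 therefore marks only a lower bound on the step, since its reading is a limit and not a number: the limit of > 40000 nM in this assay, at which 1 of the 4 values shown sits.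

From the compounds shown here alone, whether the same direction holds on any core beyond these two remains open. Also open, going by these compounds, is how an aryl group carrying an amine or a carboxylic acid would read on the aromatic nitrogen in this assay.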